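The compounds below may be only part of what the source reports. "The series", "measured", "known", "first", "only" and "open" are said of these compounds alone.

Series notes. Compound 1 `COc1cc(-n2cnc3ccc(-c4cccc(N)c4)cc32)cc(OC)c1OC` gives 640 nM in a functional assay on A549 cells (Homo sapiens) for antiproliferative activity, read by MTT assay, with a stated time of 72 h; on this read-out higher numbers stand for weaker inhibition and lower numbers for stronger inhibition. Compound 2 `COc1cc(-c2ccc3ncn(-c4cc(OC)c(OC)c(OC)c4)c3c2)cc(OC)c1OC` returns only a limit in this assay, > 10000 nM. For the measured compounds named here, compound 3 `COc1cc(-n2cnc3ccc(-c4cccc(C)c4C)cc32)cc(OC)c1OC` gives 9250 nM in this assay, the highest of the two numbers; the single measured step, a 14-fold higher number from compound 1 to compound 3 (1.16 log units; beyond the scatter), separates it from the other number. Compound 4 `COc1cc(-n2cnc3ccc(-c4ccc(Cl)cc4Cl)cc32)cc(OC)c1OC` differs from compound 3 by 2,4-dichlorophenyl in place of 2,3-dimethylphenyl on an aromatic carbon. No measured step bears directly on this change: the step shown, a 14-fold higher number from compound 1 to compound 3 (1.16 log units; beyond the scatter), involves 3-aminophenyl rather than an exchange of one substituted phenyl for another. The step of a 1.2-fold lower number from compound 3 to compound 4 (0.06 log units; within the scatter) is therefore expected to lie within the scatter, direction uncertain. Compound 4 in this assay is estimated at 8000 nM, range 2500 nM to 25000 nM, with a real chance that only a limit is returned.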

Compound 4, half-maximal inhibitory concentration: > 10000 nM
Compound 4 was reported as a limit (the forecaster's own chance of this, stated with the estimate: 35%); middle value at least 1.2-fold (0.09 log units) from the limit.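

Compound 4 returns only a limit in this assay: the limit of > 10000 nM in this assay, at which 2 of the 4 values shown sit. The step of an at least 1.0-fold higher number from compound 3 to compound 4 (0.03 log units; that floor lies within the scatter) is only a floor, so no order can be read between 2,3-dimethylphenyl and 2,4-dichlorophenyl at this position. The second step, an at least 15-fold higher number from compound 1 to compound 4 (1.19 log units; beyond the scatter), shows that two differently substituted phenyl groups without an amino group both stand beyond the scatter from 3-aminophenyl.

Open, going by these compounds, is whether a hydroxyl, a carboxylic acid or an aminomethyl group on this phenyl would hold the number near that of compound 1. Also open, on these data alone, is how far compound 4 lies past its limit.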